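This account rests on a few compounds, and the source may have more. Where it says the series, first, only, none or still open, it means among the compounds named here.

Of the compounds shown here, three built on a shared core have been measured in an assay for inhibition of Polyunsaturated fatty acid 5-lipoxygenase (Homo sapiens), read by spectrophotometry, tested at 20 uM; on this read-out higher numbers stand for more inhibition at the one concentration tested (going by the name of the read-out) and lower numbers for less inhibition. Compound 1 `O=C(/C=C/C=C/c1ccc(F)cc1)N1CCCCC1` gives 48.7%. Compound 2 `O=C(/C=C/C=C/C=C/c1ccc(O)c(O)c1)N1CCCCC1` gives 30.3%. Compound 3 `CC(=O)Oc1ccc(/C=C/C=C/C(=O)N2CCCCC2)cc1` gives 18.3%, the lowest of the three numbers. Among the measured compounds shown here, the one measured step that reaches compound 3, a number 30.4 percentage points lower from compound 1 to compound 3 (beyond the scatter), shows that exchanging the group on this aromatic carbon can move the read-out far beyond the scatter. Compound 4 `CSc1ccc(/C=C/C=C/C(=O)N2CCCCC2)cc1` differs from compound 3 by methylsulfanyl in place of acetoxy on an aromatic carbon. For the measured compounds named here, no measured pair shows this exact exchange, so its direction is uncertain; because a number 30.4 percentage points lower from compound 1 to compound 3 (beyond the scatter) was large, a sizeable step, most likely upward, is expected for compound 4, a number 16.7 percentage points higher from compound 3 to compound 4 (beyond the scatter). Compound 4 is therefore estimated to give 35%, within 15% to 55%.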

Compound 4, a percentage reported as inhibition, at one concentration (the size of the read-out at that concentration, not a potency): 11.8%
Compound 4: middle estimate off by 23.2 percentage points, on the high side; measured number below the stated range.
By their numbers in this assay, from the lowest: compounds 4 and 3 (each within the scatter of the next); then compound 2; then compound 1.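

Acetoxy and methylsulfanyl on this aromatic carbon cannot be told apart, with the exchange giving (a number 6.5 percentage points lower from compound 3 to compound 4 (within the scatter)). Among the compounds shown here, the loss seen with acetoxy is therefore not unique to that group, as methylsulfanyl in place of fluoro gives (a number 36.9 percentage points lower from compound 1 to compound 4 (beyond the scatter)), leaving fluoro the one group of these three that stands apart. No measurement at hand explains why fluoro differs from the other two. Going by these compounds, whether a chloro group or an amine at this place would match fluoro or the other two stays open.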